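A few compounds are considered here, and "the series" means these few. Any claim that something is new, unique, unknown or untested is made for them only; others in the source may bear on it.

Of the compounds shown here, two have been tested for their effect on the growth of human lung fibroblast cells. Compound 1 `COc1ccc2nc(-c3ccccc3)cc(-c3ccccc3)c2c1` gives, in an ADME assay on CCD 19Lu cells (Homo sapiens) for antiproliferative activity, read by MTT assay, with a stated time of 24 h (a lower number here means a stronger inhibitor, a higher number a weaker inhibitor), a half-maximal inhibitory concentration of 925000 nM. Compound 2 `Clc1ccc(-c2cc(-c3ccccc3)c3cc(Br)ccc3n2)cc1` gives in this assay 528000 nM. Of the two numbers that of compound 2 is the lower, but the gap to compound 1 lies within the usual scatter of such measurements, so the two compounds cannot be told apart on these data.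

Compound 3 `Oc1ccc(-c2cc(-c3ccccc3)c3cc(Br)ccc3n2)cc1` is not yet measured. It differs from compound 2 in one place: hydroxy in place of chloro on an aromatic carbon, so that a 4-chlorophenyl group becomes a 4-hydroxyphenyl group. For the measured compounds named here, no measured pair shows this change. With both known numbers so high and so close, the step from compound 2 to compound 3 is expected to be small, a 1.1-fold higher number from compound 2 to compound 3 (0.06 log units; within the scatter), in no set direction beyond the scatter. Compound 3 is therefore estimated at 600000 nM, within a range of 250000 nM to 1500000 nM.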

Compound 3, half-maximal inhibitory concentration: 104000 nM
Estimate against measurement, compound 3: 5.8-fold (0.76 log units) above, outside the stated range (below it).
By their numbers in this assay, from the lowest: compound 3; then compounds 2 and 1 (each within the scatter of the next).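

Exchanging a 4-chlorophenyl group for a 4-hydroxyphenyl group in this assay gives a 5.1-fold lower number from compound 2 to compound 3 (0.71 log units; beyond the scatter) and so shows that this position responds to a change of a single atom, which compounds 1 and 2, differing in more than one place, could not show. The change adds a hydrogen-bond donor and a hydrogen-bond acceptor, but this is only a difference between the two structures and is not shown to account for the lower number. Nothing measured here explains the step.

From the compounds shown here alone, it remains open whether the hydroxy group is special or whether other groups at this position, such as an amine or a carboxylic acid, would give a similar number. Going by these compounds, it is also open whether the same exchange would have a similar effect on a different core.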